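The compounds below may be only part of what the source reports. "The series", "measured", "known", "first", "only" and "open" are said of these compounds alone.

Compound 1 `O=C([C@H]1CCN1S(=O)(=O)c1c(F)c(F)c(F)c(F)c1F)N(Cc1ccc(C2CCCCC2)cn1)c1ccc2c(=O)[nH]cnc2c1` gives 3300 nM in a functional assay on MDA-MB-231 cells (Homo sapiens) for antiproliferative activity, with a stated time of 72 h; on this read-out lower numbers stand for an effect already at smaller amounts and higher numbers for an effect only at larger amounts of compound. Compound 2 `O=C([C@H]1CCN1S(=O)(=O)c1c(F)c(F)c(F)c(F)c1F)N(Cc1cnc(C2CCCCC2)cn1)c1ccc2c(=O)[nH]cnc2c1` carries 5-cyclohexylpyrazin-2-yl in place of 5-cyclohexylpyridin-2-yl on a saturated chain carbon bound to an amide-type nitrogen and in this assay compound 2 gives 4200 nM, so that a 1.3-fold higher number from compound 1 to compound 2 (0.10 log units; within the scatter). Compound 3 `O=C([C@H]1CCN1S(=O)(=O)c1c(F)c(F)c(F)c(F)c1F)N(Cc1ccc(C2CCCCC2)cn1)c1cc2[nH]ncc2cc1F` differs from compound 1 in its core, with a group of 10 heavy atoms (7 carbon, 2 nitrogen, 1 fluorine; one five-membered aromatic ring with 2 hetero atoms, one six-membered aromatic ring of carbon only) in place of a group of 11 heavy atoms (8 carbon, 2 nitrogen, 1 oxygen; one six-membered aromatic ring of carbon only, one six-membered aromatic ring with 2 hetero atoms), on an amide-type nitrogen, and in this assay compound 3 gives 2300 nM, a step in which a 1.4-fold lower number from compound 1 to compound 3 (0.16 log units; within the scatter). Compound 4 `O=C([C@H]1CCN1S(=O)(=O)c1c(F)c(F)c(F)c(F)c1F)N(Cc1cnc(C2CCCCC2)cn1)c1cc2[nH]ncc2cc1F` is not yet measured; it carries 5-cyclohexylpyrazin-2-yl in place of 5-cyclohexylpyridin-2-yl on a saturated chain carbon bound to an amide-type nitrogen, the same change as that from compound 1 to compound 2, now made on the core of compound 3. Because a 1.3-fold higher number from compound 1 to compound 2 (0.10 log units; within the scatter), the step from compound 3 to compound 4 is expected to be of similar, small size, a 1.3-fold higher number from compound 3 to compound 4 (0.10 log units; within the scatter). Compound 4 is therefore estimated at 2900 nM in this assay, between 1400 nM and 6000 nM.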

Compound 4, half-maximal effective concentration: 2000 nM
Beside the measured number, compound 4's estimate is 1.5-fold (0.16 log units) above it; the range from low to high includes it.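

In this assay, putting 5-cyclohexylpyrazin-2-yl in place of 5-cyclohexylpyridin-2-yl gives a 1.2-fold lower number from compound 3 to compound 4 (0.06 log units; within the scatter), and this agrees with the earlier step on the other core: the same change on two cores in this assay, a 1.3-fold higher number (0.10 log units; within the scatter) from compound 1 to compound 2 and a 1.2-fold lower number (0.06 log units; within the scatter) from compound 3 to compound 4, 1.5-fold (0.17 log units) apart, within the scatter of two such steps. The change of core, read with 5-cyclohexylpyrazin-2-yl in place, gives a 2.1-fold lower number from compound 2 to compound 4 (0.32 log units; beyond the scatter), which alone lies beyond the scatter but does not differ from the same change read with 5-cyclohexylpyridin-2-yl: the same change on two cores in this assay, a 1.4-fold lower number (0.16 log units; within the scatter) from compound 1 to compound 3 and a 2.1-fold lower number (0.32 log units; beyond the scatter) from compound 2 to compound 4, 1.5-fold (0.17 log units) apart, within the scatter of two such steps. The exchange thus carries over between these two cores as a step too small to separate from the scatter, which does not show that it would behave alike on any further core or in another assay.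

The compounds shown leave open what happens when the cyclohexyl ring gives way to a phenyl ring or a longer alkyl chain. They also leave open whether an amine or a carboxylic acid placed on that ring would shift the number.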